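The compounds below may be only part of what the source reports. "The series", "measured", "known", "first", "only" and "open" are said of these compounds alone.

In a functional assay on HCT-116 cells (Homo sapiens) for inhibition, read by MTT assay, with a stated time of 48 h (a higher number here means a weaker inhibitor, a lower number a stronger inhibitor), compound 3 `COc1ccc(-c2cc(-c3cc(OC)c(OC)c(OC)c3)nc(-c3ccccc3)n2)cc1` gives 4780 nM and compound 1 `COc1cc(-c2cc(-c3ccc(Br)cc3)nc(-c3ccccc3)n2)cc(OC)c1OC` gives 4320 nM, two values within the scatter of each other. Compound 2 `COc1cc(-c2cc(-c3cccc([N+](=O)[O-])c3)nc(-c3ccccc3)n2)cc(OC)c1OC` is reported only as a limit of the assay, > 25000 nM. Compound 4 `COc1cc(-c2cc(-c3cccc4ccccc34)nc(-c3ccccc3)n2)cc(OC)c1OC` differs from compound 3 by naphthalen-1-yl in place of 4-methoxyphenyl on an aromatic carbon, with naphthalen-1-yl in place of 4-methoxyphenyl on an aromatic carbon. Measured changes at this place bear on it: a 1.1-fold higher number from compound 1 to compound 3 (0.04 log units; within the scatter), yet an at least 5.7-fold higher number from compound 1 to compound 2 (0.76 log units; beyond the scatter) and an at least 5.2-fold lower number from compound 2 to compound 3 (0.71 log units; beyond the scatter). Going by the values given here, compound 2 thus goes against any flat pattern, and no measured compound carries naphthalen-1-yl. The expected change is a 1.2-fold higher number from compound 3 to compound 4 (0.06 log units; within the scatter), so no step beyond the scatter is expected, though a loss like that of compound 2 remains possible. For compound 4 the estimated value is 5500 nM, within an expected range of 2000 nM to 18000 nM.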

Compound 4, half-maximal inhibitory concentration: 4930 nM
Estimate against measurement, compound 4: 1.1-fold (0.05 log units) above; low and high end bracket the measured number.
By their numbers in this assay, from the lowest: compounds 1, 3 and 4 (each within the scatter of the next). At a limit, above all of these: compound 2.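

In this assay, naphthalen-1-yl at this position reads the same as the single-ring groups, with a 1.0-fold higher number from compound 3 to compound 4 (0.01 log units; within the scatter) and a 1.1-fold higher number from compound 1 to compound 4 (0.06 log units; within the scatter), so a second six-membered aromatic ring leaves the number unchanged. Only 3-nitrophenyl goes against this flat pattern, with an at least 5.0-fold lower number from compound 2 to compound 4 (0.70 log units; beyond the scatter). Compound 2 is reported only as a limit: the limit of > 25000 nM in this assay, at which 1 of the 4 values shown sits.

The compounds shown leave open whether the loss with compound 2 belongs to the nitro group itself or to its place on the phenyl ring. They also leave open how an amine or a carboxylic acid on that ring would read.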